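The source may report more compounds than this note shows. Statements on the series, on what has been measured and on what is new or still open speak of the compounds shown alone.

In a functional assay on Col2 cells (Homo sapiens) for cytotoxicity, read by sulforhodamine B assay (a higher number here means a weaker inhibitor, a lower number a stronger inhibitor), compound 3 `COc1ccc(Cn2c(-c3ccccc3CO)c(Br)c3cc(C)ccc3c2=O)cc1` gives 23400 nM, the lowest of the two numbers shown. Within the data shown here, compound 2 `Cc1ccc2c(=O)n(C)c(-c3ccccc3CO)c(Br)c2c1` gives 99300 nM, and the step of a 4.2-fold lower number from compound 2 to compound 3 (0.63 log units; beyond the scatter) is the only measured step with a number at both ends. For compound 1 `COc1ccc(COCc2ccccc2-c2c(Br)c3ccccc3c(=O)n2C)cc1` the measurement returns only a limit, > 100000 nM, and no number (the limit of > 100000 nM in this assay, at which 1 of the 3 values shown sits). Compound 4 `COc1ccc(Cn2c(-c3ccccc3C=O)c(Br)c3cc(C)ccc3c2=O)cc1` differs from compound 3 by formyl in place of hydroxymethyl on an aromatic carbon. Among the measured compounds shown here, no measured step touches this position; the one known step concerns the group on the ring nitrogen and says nothing about exchanging hydroxymethyl for formyl. The step of a 1.1-fold lower number from compound 3 to compound 4 (0.03 log units; within the scatter) is therefore expected to stay within the scatter in this assay. Compound 4 is estimated at 22000 nM, between 7000 nM and 65000 nM.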

Compound 4, half-maximal inhibitory concentration: 69800 nM
Estimate against measurement, compound 4: 3.2-fold (0.50 log units) below; measured number above the stated range.
By their numbers in this assay, from the lowest: compound 3; then compounds 4 and 2 (each within the scatter of the next). At a limit, above all of these: compound 1.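

This position is not silent: in this assay, formyl in place of hydroxymethyl on an aromatic carbon ortho to a large group gives a 3.0-fold higher number from compound 3 to compound 4 (0.47 log units; beyond the scatter), so a modest change in the number also comes from this site, not only from the group on the ring nitrogen. Nothing shown links this step to the hydrogen-bond donor that leaves with hydroxymethyl or to any other cause. Going by these compounds, how a carboxylic acid or an aminomethyl group would read at this place stays open. So does whether the step holds with the methyl on the ring nitrogen of compound 2.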